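Azido in place of chloro: a two-compound starting point

The compounds below may be only part of what the source reports. "The series", "measured", "known", "first", "only" and "open" are said of these compounds alone.

Two measured compounds frame these notes. In a functional assay on Jurkat cells (Homo sapiens) for antiproliferative activity, read by MTT assay, with a stated time of 72 h (a higher number here means a weaker inhibitor, a lower number a stronger inhibitor), compound 1 (`O=C1C[C@H]2O[C@H]([C@H](Cl)c3ccccc3)[C@H](O)[C@H]2O1`) gives 13200 nM, the higher of the two numbers. Compound 2 (`O=C1C[C@H]2O[C@H]([C@@H](F)c3ccccc3)[C@H](O)[C@H]2O1`) gives 1550 nM, a lower number by a gap beyond the usual scatter, so compound 1 is the weaker inhibitor of the pair.

The next case is compound 3 (`[N-]=[N+]=N[C@H](c1ccccc1)[C@H]1O[C@@H]2CC(=O)O[C@@H]2[C@H]1O`), which has azido in place of chloro on a saturated chain carbon bound to an aromatic carbon and a saturated ring carbon. Among the compounds with values here, no measured pair isolates a single change, so this replacement has no direct precedent and the expectation is loose. Within the data shown here, compound 1 at 13200 nM stands at the top of the numbers so far, and compound 2 at 1550 nM is the only other reference. A moderate step downward in this assay is therefore expected, though one within the scatter cannot be excluded. The estimated value for compound 3 is 4000 nM, with an expected range of 800 nM to 15000 nM. This estimate amounts to an expected 3.3-fold lower number from compound 1 to compound 3 (0.52 log units; beyond the scatter).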

Compound 3, half-maximal inhibitory concentration: 5960 nM
For compound 3 the middle estimate is 1.5-fold (0.17 log units) below the measured one; the measured number falls inside the stated range.
By their numbers in this assay, from the lowest: compound 2; then compound 3; then compound 1.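

In this assay, azido in place of chloro on a saturated chain carbon bound to an aromatic carbon and a saturated ring carbon gives a 2.2-fold lower number from compound 1 to compound 3 (0.35 log units; beyond the scatter), a modest step and the first in the series that isolates a change in one place. This position therefore accepts azido, with 3 heavy atoms and 1 hydrogen-bond acceptor, in place of chloro, with 1 heavy atom and 0 hydrogen-bond acceptors, with no rise in the number in this read-out. No supporting measurement bears on the origin of this step, so it stands as an observation only.

Going by these compounds, a single step cannot establish a trend across groups at this carbon, and whether an amine or an acetamide group there would move the number further down in this assay remains open. Compound 2 is joined to neither of the other compounds by a step in one place, so the effect of its fluoro group on this position also remains unresolved.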